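Swapping 4-bromophenyl for acetamido on the shared core

The source may hold more compounds than are shown below. What is called first, only, known or untested is meant among the compounds shown, and "the series" means these compounds.

compound 1 `N=c1oc2ccccc2cc1C(=O)N/N=C1\C(=O)Nc2ccc(S(=O)(=O)N3CCOCC3)cc21`: 6750 nM
compound 2 `O=C1Nc2ccc(S(=O)(=O)N3CCOCC3)cc2/C1=N/c1ccc(Br)cc1`: 15300 nM
compound 3 `Cc1ccc(S(=O)(=O)N/N=C2\C(=O)Nc3ccc(S(=O)(=O)N4CCOCC4)cc32)cc1`: 23400 nM

In a functional assay on HCT-116 cells (Homo sapiens) for cytotoxicity, read by sulforhodamine B assay, with a stated time of 24 h (on this read-out lower numbers stand for stronger inhibition and higher numbers for weaker inhibition), compound 2 gives 15300 nM. That value lies within the scatter of compound 3, while compound 1 shows a lower number, beyond the scatter. Compound 4 `CC(=O)N/N=C1\C(=O)Nc2ccc(S(=O)(=O)N3CCOCC3)cc21` has acetamido in place of 4-bromophenyl on a double-bonded nitrogen. Among the measured compounds shown here, no two measured compounds differ in only one place, so the guide is weak. Like compound 4, compound 1 (6750 nM) and compound 3 (23400 nM) carry a second nitrogen at that place, and their values leave the direction open. In this assay, the expected 1.3-fold higher number from compound 2 to compound 4 (0.12 log units; within the scatter) is no change beyond the scatter. For compound 4 the estimated value is 20000 nM, with an expected range of 8000 nM to 50000 nM.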

Compound 4, half-maximal inhibitory concentration: 29000 nM
Estimate against measurement, compound 4: 1.5-fold (0.16 log units) below; the range from low to high includes it.
By their numbers in this assay, from the lowest: compound 1; then compounds 2, 3 and 4 (each within the scatter of the next).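

In this assay, acetamido in place of 4-bromophenyl on a double-bonded nitrogen gives a 1.9-fold higher number from compound 2 to compound 4 (0.28 log units; within the scatter), and acetyl in place of (4-methylphenyl)sulfonyl on an amine nitrogen gives a 1.2-fold higher number from compound 3 to compound 4 (0.09 log units; within the scatter), so neither swap can be told from no change. Cutting the group of 11 heavy atoms on a carbonyl carbon down to one carbon atom gives a 4.3-fold higher number from compound 1 to compound 4 (0.63 log units; beyond the scatter), the only step here that clears the scatter, and it is modest.

No measurement shown explains these steps. Going by these compounds, whether a smaller group such as an amine, or a carboxylic acid, on that carbonyl carbon would shift the number stays open.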